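Steps on the saturated ring of the pyrazole series

A few compounds are considered here, and "the series" means these few. Any claim that something is new, unique, unknown or untested is made for them only; others in the source may bear on it.

Measured so far:
- compound 1 `COc1ccccc1-n1nc(C2CCOC(C)(C)C2)cc1-c1ccc(Cl)cc1`: 55 nM
- compound 2 `COc1ccccc1-n1nc([C@@H]2CCO[C@@H](C(C)C)C2)cc1-c1ccc(Cl)cc1`: "not determined" (no result reported)
- compound 3 `COc1ccccc1-n1nc([C@@H]2CCO[C@H](C(C)C)C2)cc1-c1ccc(Cl)cc1`: 55000 nM

In an assay on HEK293 cells for inhibition of Voltage-dependent N-type calcium channel subunit alpha-1B (Homo sapiens), read by patch clamp, using a membrane potential dye (on this read-out lower numbers stand for stronger inhibition and higher numbers for weaker inhibition), compound 3 gives the highest number of the two reported; the nearest is compound 1 with 55 nM, the step of a 1000-fold higher number from compound 1 to compound 3 (3.00 log units; beyond the scatter) being large. For the measured compounds named here, compound 2 has no reported number, and the fact that compounds 2 and 3 differ only in the configuration as drawn is the only point of comparison between compounds 2 and 3.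

Compound 4 `COc1ccccc1-n1nc(C2=CC(C)(C)OC(C)(C)C2)cc1-c1ccc(Cl)cc1` carries a group of 10 heavy atoms (9 carbon, 1 oxygen; one six-membered non-aromatic ring with 1 hetero atom) in place of a group of 9 heavy atoms (8 carbon, 1 oxygen; one six-membered non-aromatic ring with 1 hetero atom), on an aromatic carbon. Going by the values given here, the one measured step that bears on it is a 1000-fold higher number from compound 1 to compound 3 (3.00 log units; beyond the scatter), which runs in the opposite direction. Compound 4 restores the 2,2-dimethyl motif of compound 1 while adding a further pair of methyls and a double bond, so a large fall in the number is expected, a 180-fold lower number from compound 3 to compound 4 (2.26 log units; beyond the scatter), though not the full return to compound 1. Compound 4 is estimated at 300 nM, within 30 nM to 3000 nM.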

Compound 4, half-maximal inhibitory concentration: 26000 nM
For compound 4 the middle estimate is 87-fold (1.94 log units) below the measured one; measured number above the stated range.
By their numbers in this assay, from the lowest: compound 1; then compound 4; then compound 3.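

The ring of compound 4 brings only a 2.1-fold lower number from compound 3 to compound 4 (0.33 log units; beyond the scatter) as a modest gain, so most of the loss seen with compound 3 remains. The 2,2-dimethyl pattern alone is not enough at this position, with a 470-fold higher number from compound 1 to compound 4 (2.67 log units; beyond the scatter) still standing as a large gap. Nothing available bears on the cause of this result.

Open, on these data alone, is whether the added methyls or the double bond carries the loss in compound 4. Also open, as far as these compounds go, is how plain oxan-4-yl, or an amine on the saturated ring, would read here.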